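Spiro core amide tail: aminobutyl in place of hydroxypiperidinyl

The source may hold more compounds than are shown below. What is called first, only, known or untested is meant among the compounds shown, and "the series" means these compounds.

Two members of the series carry numbers in an assay on HEK293 cells for displacement of a labelled ligand from NPC1-like intracellular cholesterol transporter 1 (Homo sapiens); a higher number here means a weaker inhibitor, a lower number a stronger inhibitor. Compound 1 `CC(C)(C)c1ccc(C(=O)N2CCC3(CC2)C(=O)N(CC(=O)NCCN)CN3c2ccccc2)cc1` gives 7000 nM. Going by the values given here, compound 2 `CC(C)(C)c1ccc(C(=O)N2CCC3(CC2)C(=O)N(CC(=O)N2CCC(O)CC2)CN3c2ccccc2)cc1` gives 4700 nM, and the only step on record, a 1.5-fold lower number from compound 1 to compound 2 (0.17 log units; within the scatter), leaves the two indistinguishable. Compound 3 `CC(C)(C)c1ccc(C(=O)N2CCC3(CC2)C(=O)N(CC(=O)NCCCCN)CN3c2ccccc2)cc1` differs from compound 2 by (4-aminobutyl)amino in place of 4-hydroxypiperidin-1-yl on a carbonyl carbon. Among the compounds with values here, the one measured step concerned this same carbonyl carbon and stayed within the scatter, so for compound 3 the expected step is a 1.3-fold higher number from compound 2 to compound 3 (0.11 log units; within the scatter), none beyond the scatter. Compound 3 is therefore estimated at 6000 nM in this assay, with a range from 2500 nM to 15000 nM.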

Compound 3, half-maximal inhibitory concentration: 14500 nM
The estimate for compound 3 lay 2.4-fold (0.38 log units) below the measured number; the range from low to high includes it.
By their numbers in this assay, from the lowest: compounds 2 and 1 (each within the scatter of the next); then compound 3.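

Going by these compounds alone, on the carbonyl carbon, (4-aminobutyl)amino in place of 4-hydroxypiperidin-1-yl gives the first step beyond the scatter, though a modest one (a 3.1-fold higher number from compound 2 to compound 3 (0.49 log units; beyond the scatter)). Chain length also registers: 2-aminoethyl in place of amino on the saturated chain carbon gives a modest step of its own (a 2.1-fold higher number from compound 1 to compound 3 (0.32 log units; beyond the scatter)). No evidence is available on what lies behind either step.

From the compounds shown here alone, whether a still longer aminoalkyl chain would continue this trend remains open. So does the effect of a carboxylic acid at the chain end in place of the amine.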